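Solubility notes on a pyrazolopyrimidinone thioether series

This account rests on a few compounds, and the source may have more. Where it says the series, first, only, none or still open, it means among the compounds named here.

Measured so far:
compound 1 `O=c1c2cn(C3COC3)nc2nc(SCc2cccc(F)c2)n1-c1ccccc1`: 5000 nM
compound 2 `CC(Sc1nc2c(cnn2C)c(=O)n1-c1ccccc1)c1ccccc1`: 8000 nM
compound 3 `CC(Sc1nc2nn(C3COC3)cc2c(=O)n1-c1ccccc1)c1ccccn1`: 60000 nM

In a physicochemical assay for solubility, using the shake flask method, in phosphate buffer, with a stated time of 24 h, at pH 7.4 (a higher number here means a more soluble compound, a lower number a less soluble compound), compound 2 holds the second highest of the three numbers; its gap to compound 1 lies within the scatter, while compound 3 sits clearly higher. Compound 4 `CC(Sc1nc2c(cnn2C)c(=O)n1-c1ccccc1)c1cncnc1` is not yet measured. It differs from compound 2 in one place: pyrimidin-5-yl in place of phenyl on a saturated chain carbon bound to a saturated chain carbon and a sulfur.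

Within the data shown here, one measured step bears on this change. From compound 1 to compound 3 a carbon-only aromatic ring on the sulfur-bound side chain gave way to a nitrogen-containing one, among other alterations, and this assay rose: a 12-fold higher number from compound 1 to compound 3 (1.08 log units; beyond the scatter). Among the measured compounds shown here, that step is not a clean match, since the chain itself also changed, but it is the only guidance here, and it points upward.

For compound 4 an increase beyond the scatter in this assay is therefore expected, a 3.8-fold higher number from compound 2 to compound 4 (0.57 log units; beyond the scatter), though smaller than that seen for compound 3. The estimate for compound 4 is 30000 nM, with a range from 10000 nM to 100000 nM.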

Compound 4, solubility: 264000 nM
Compound 4: middle estimate off by 8.8-fold (0.94 log units), on the low side, and the stated range ends below it.
By their numbers in this assay, from the lowest: compounds 1 and 2 (each within the scatter of the next); then compound 3; then compound 4.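

With the 1-phenylethyl group swapped for 1-(pyrimidin-5-yl)ethyl and nothing else altered, this assay gives a clean reading of the ring change alone: a 33-fold higher number from compound 2 to compound 4 (1.52 log units; beyond the scatter). The earlier step to a nitrogen-containing ring also changed the chain and was read on the core of compound 1, whereas this one keeps the saturated chain carbon bound to a saturated chain carbon and a sulfur and is read on the core of compound 2. Nothing shown accounts for the size of this step.

Still open, on these data alone, is how the step depends on the ring nitrogens, which a pyridin-3-yl or a pyridazin-4-yl on the same chain carbon would help to settle. As far as these compounds go, it is also open whether the same pyrimidin-5-yl change carries over to the core of compound 1.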